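A few compounds are considered here, and "the series" means these few. Any claim that something is new, unique, unknown or untested is made for them only; others in the source may bear on it.

In an assay for inhibition of prostacyclin synthase (Homo sapiens), using microsomes (on this read-out lower numbers stand for stronger inhibition and higher numbers for weaker inhibition), compound 1 `Cc1ccc(OC(C)(C)C2OCC(C/C=C\CCC(=O)O)C(c3cccnc3)O2)cc1` gives 25000 nM, and compound 2 `CC(C)(Oc1ccccc1Br)C1OCC(C/C=C\CCC(=O)O)C(c2cccnc2)O1` gives 7000 nM. The change gave a 3.6-fold lower number from compound 1 to compound 2 (0.55 log units; beyond the scatter), so compound 2 stands with the lowest of the two numbers. Compound 3 `CC(C)(Oc1ccc(F)cc1[N+](=O)[O-])C1OCC(C/C=C\CCC(=O)O)C(c2cccnc2)O1` differs from compound 2 only by 4-fluoro-2-nitrophenyl in place of 2-bromophenyl on an oxygen on a saturated carbon. Among the measured compounds shown here, the single step that bears on this, an exchange of the aryl group on the same oxygen, was modest. Compound 3 is therefore expected near compound 2, with a step of a 1.1-fold higher number from compound 2 to compound 3 (0.06 log units; within the scatter), and its estimated value in this assay is 8000 nM, within 2500 nM to 25000 nM.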

Compound 3, half-maximal inhibitory concentration: 9000 nM
Beside the measured number, compound 3's estimate is 1.1-fold (0.05 log units) below it; the range from low to high includes it.
By their numbers in this assay, from the lowest: compounds 2 and 3 (each within the scatter of the next); then compound 1.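

In this assay, 4-fluoro-2-nitrophenyl in place of 2-bromophenyl on this oxygen gave a 1.3-fold higher number from compound 2 to compound 3 (0.11 log units; within the scatter), so this larger aryl group, which brings hydrogen-bond acceptors, leaves the number within the scatter of compound 2. In place of 4-methylphenyl, the same group gave a 2.8-fold lower number from compound 1 to compound 3 (0.44 log units; beyond the scatter), so both exchanges away from compound 1 now lower the number. Nothing available explains these steps. As far as these compounds go, whether an aryl group carrying an amine or a carboxylic acid would lower the number further stays open. So does the effect of plain phenyl here.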